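Notes on a diazabicyclic nicotinamide series, third analogue

The source may report more compounds than this note shows. Statements on the series, on what has been measured and on what is new or still open speak of the compounds shown alone.

Measured so far in an assay on cells for displacement of a labelled ligand from Neuronal acetylcholine receptor; alpha3/beta4 (Homo sapiens); on this read-out higher numbers stand for weaker inhibition and lower numbers for stronger inhibition:
compound 1 `O=C(Nc1cccc(F)c1)c1cncc(N2CC3CC(C2)N3)c1`: 28 nM
compound 2 `O=C(Nc1ccc(F)cc1)c1cncc(N2CC3CC(C2)N3)c1`: 81 nM

Among the compounds with values here, compound 2 stands with the higher number of the two measured compounds; the single measured step is a 2.9-fold higher number from compound 1 to compound 2 (0.46 log units; beyond the scatter), a change of the fluoro-bearing ring from 3-fluorophenyl to 4-fluorophenyl on the amide-type nitrogen.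

Compound 3 `O=C(Nc1ccc(Cl)cc1)c1cncc(N2CC3CC(C2)N3)c1` has not yet been measured in this assay. It differs from compound 2 by chloro in place of fluoro on an aromatic carbon. Within the data shown here, no measured step bears directly on this exchange: the one known step, a 2.9-fold higher number from compound 1 to compound 2 (0.46 log units; beyond the scatter), keeps fluoro and changes only where it sits, so it gives no guide to the size or direction of a halogen swap. With nothing in the series pointing either way, the expectation for compound 3 is a step of a 1.0-fold lower number from compound 2 to compound 3 (0.01 log units; within the scatter) that stays within the scatter. Compound 3 is therefore estimated at 80 nM, with a range from 30 nM to 220 nM.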

Compound 3, inhibition constant: 123 nM
For compound 3 the middle estimate is 1.5-fold (0.19 log units) below the measured one, and the stated range covers the measured number.
By their numbers in this assay, from the lowest: compound 1; then compounds 2 and 3 (each within the scatter of the next).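

In this assay, exchanging fluoro for chloro on the aromatic carbon para to a large group gives a 1.5-fold higher number from compound 2 to compound 3 (0.18 log units; within the scatter), so the two halogens cannot be told apart at this place. The comparison with the other ring pattern gives a 4.4-fold higher number from compound 1 to compound 3 (0.64 log units; beyond the scatter), which places compound 1 with the lowest number in the series, its steps to both other compounds lying beyond the scatter. Nothing available accounts for either step.

As far as these compounds go, it remains open whether the lower number of compound 1 depends on fluoro itself or would hold with chloro in the place fluoro occupies there. Also open, from the compounds shown here alone, is whether the tolerance seen para to the large group extends beyond halogens, for example to a methoxy group, a nitrile or an amine.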